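Branching of the thiourea substituent in a flavanone-type series

The source may report more compounds than this note shows. Statements on the series, on what has been measured and on what is new or still open speak of the compounds shown alone.

Compound 1 `CC(C)NC(=S)N/N=C1\CC(c2ccc(O)cc2)Oc2cc(O)ccc21`: 38200 nM
Compound 2 `Oc1ccc(C2C/C(=N\NC(=S)N3CCOCC3)c3ccc(O)cc3O2)cc1`: 63500 nM
Compound 3 `CC(C)(C)NC(=S)N/N=C1\CC(c2ccc(O)cc2)Oc2cc(O)ccc21`: 25900 nM

All three were measured in a functional assay on HCT-116 cells (Homo sapiens) for cytotoxicity, read by MTT assay, with a stated time of 72 h; a lower number here means a stronger inhibitor, a higher number a weaker inhibitor. Among the compounds with values here, compound 3 gives the lowest of the three numbers, but its gap to compound 1 is within the scatter, a 1.5-fold lower number from compound 1 to compound 3 (0.17 log units; within the scatter); only the step of a 2.5-fold lower number from compound 2 to compound 3 (0.39 log units; beyond the scatter) is beyond it. Compound 4 `CCCCNC(=S)N/N=C1\CC(c2ccc(O)cc2)Oc2cc(O)ccc21` differs from compound 3 by butyl in place of tert-butyl on an amide-type nitrogen. Within the data shown here, the nearest measured guide is a 1.5-fold lower number from compound 1 to compound 3 (0.17 log units; within the scatter), where one branched alkyl replaced another without effect beyond the scatter; no measured step exchanges a branched for an unbranched chain. Compound 4 is therefore expected to move little, a 1.2-fold higher number from compound 3 to compound 4 (0.09 log units; within the scatter), and its estimated value is 32000 nM, with a range from 13000 nM to 80000 nM.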

Compound 4, half-maximal inhibitory concentration: 49300 nM
Compound 4: the middle estimate sits 1.5-fold (0.19 log units) below what was measured; measured number inside the range.
By their numbers in this assay, from the lowest: compounds 3, 1, 4 and 2 (each within the scatter of the next, the first and the last beyond it).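

In this assay, the exchange of a branched chain for an unbranched one with the same carbon count on this amide-type nitrogen stays within the scatter (a 1.9-fold higher number from compound 3 to compound 4 (0.28 log units; within the scatter)). Butyl also cannot be told apart from isopropyl (a 1.3-fold higher number from compound 1 to compound 4 (0.11 log units; within the scatter)) or from morpholin-4-yl on the thiocarbonyl carbon (a 1.3-fold lower number from compound 2 to compound 4 (0.11 log units; within the scatter)), so in these compounds the shape of the chain has no resolved effect at this position. Nothing available explains these numbers. Going by these compounds, whether a cyclohexyl or phenyl group, or a longer chain such as octyl, on this nitrogen would give a step beyond the scatter remains open.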